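This account rests on a few compounds, and the source may have more. Where it says the series, first, only, none or still open, it means among the compounds named here.

The measured compounds:
Compound 1, `Cc1noc(-c2nc(C)c3c(c2N)C(=O)N(Cc2ccc(C(F)(F)F)cc2)C3=O)n1`, in a physicochemical assay for solubility, using the shake flask method, in simulated intestinal fluid, measured as kinetic solubility, with a stated time of 2 h, at 25 degrees C, at pH 6.5 (a lower number here means a less soluble compound, a higher number a more soluble compound), gives < 5000 nM, which is a limit of the assay and not a number.
Compound 2, `COc1ccc(CN2C(=O)c3c(C)nc(-c4nc(C)no4)c(N)c3C2=O)cc1`, in this assay gives < 5000 nM, again a limit of the assay.
Compound 3, `Cc1noc(-c2nc(C)c3c(c2N)C(=O)N(Cc2cccc(C(F)(F)F)c2)C3=O)n1`, in this assay gives < 5000 nM, also a limit of the assay.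

All three values sit at the same limit, (the limit of < 5000 nM in this assay, at which 3 of the 3 values shown sit). From compound 1 to compound 2 the change is methoxy in place of trifluoromethyl on an aromatic carbon, and the step is a step that the two limits leave unreadable from compound 1 to compound 2. From compound 1 to compound 3 the two cores differ as 3-(trifluoromethyl)phenyl in place of 4-(trifluoromethyl)phenyl on a saturated chain carbon bound to an amide-type nitrogen in a ring, and the step is a step that the two limits leave unreadable from compound 1 to compound 3. Between compound 2 and compound 3 the step is a step that the two limits leave unreadable from compound 2 to compound 3.

Compound 4, `COc1cccc(CN2C(=O)c3c(C)nc(-c4nc(C)no4)c(N)c3C2=O)c1`, has not yet been measured in this assay. It differs from compound 3 by methoxy in place of trifluoromethyl on an aromatic carbon. Among the compounds with values here, this is the same kind of change as the one from compound 1 to compound 2, not the same: there the group sits para to a large group, here it sits meta to a large group. The earlier step has no readable size; both of its values are limits, so nothing can be copied from it.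

Compound 3 gives < 5000 nM, and every measured compound sits at the limit of < 5000 nM in this assay, at which 3 of the 3 values shown sit. Compound 4 is expected to give 3000 nM, most likely once more reported only as the limit, with an expected range from 800 nM to 7000 nM. The expected step is a step that the limit leaves unreadable from compound 3 to compound 4.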

Compound 4, solubility: < 5000 nM
Compound 4 gave a limit, no number; the forecaster's own chance of this, stated with the estimate: 85%; the middle value is on the limit's open side.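

Compound 4 joins compound 1, compound 2 and compound 3 at the same limit in this assay: the limit of < 5000 nM in this assay, at which 4 of the 4 values shown sit. Within the data shown here, no step from compound 1, compound 2 or compound 3 to compound 4 can be read; each joins two limits, which gives no size. Going by these compounds, how the four compounds truly rank in this assay, and whether swapping trifluoromethyl for methoxy or 3-methoxyphenyl for 4-methoxyphenyl changes the result at all, stays open.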